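A few compounds are considered here, and "the series" means these few. Any claim that something is new, unique, unknown or untested is made for them only; others in the source may bear on it.

In an ADME assay on HaCaT cells (Homo sapiens) for cytotoxicity, read by MTT assay, with a stated time of 48 h (a lower number here means that less compound is needed, a higher number that more compound is needed for the effect), compound 1 `CCCCOC(=O)[C@@H](N)CCC(=O)NCCSC(=O)C(C)(C)C` gives 102000 nM and compound 2 `CCCOC(=O)[C@@H](N)CCC(=O)NCCSC(C)=O` gives 548000 nM as the higher of the two numbers, beyond the usual scatter from compound 1. Compound 3 `CCCOC(=O)[C@@H](N)CCC(=O)NCCSC(=O)C(C)(C)C` differs from compound 2 by one change: tert-butyl in place of methyl on a carbonyl carbon. Compound 1 also carries tert-butyl there and stands at 102000 nM so a number clearly lower than that of compound 2 is expected for compound 3 in this assay as well. The step of a 3.7-fold lower number from compound 2 to compound 3 (0.56 log units; beyond the scatter) is the expected change. For compound 3 the estimate is 150000 nM with an expected range from 70000 nM to 350000 nM in this measurement.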

Compound 3, half-maximal effective concentration: 152000 nM
Compound 3: middle estimate off by 1.0-fold (0.01 log units), on the low side, and the stated range covers the measured number.
By their numbers in this assay, from the lowest: compounds 1 and 3 (each within the scatter of the next); then compound 2.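

In this assay the change from methyl to tert-butyl on a carbonyl carbon whose other neighbour is sulfur can now be read on its own, with a 3.6-fold lower number from compound 2 to compound 3 (0.56 log units; beyond the scatter) as its single-place step. With tert-butyl kept, hydrogen in place of methyl on the saturated chain gives a 1.5-fold higher number from compound 1 to compound 3 (0.17 log units; within the scatter) and so does not separate these two compounds. No measurement shown gives a reason for either step. Still open, as far as these compounds go, is how an isopropyl or phenyl group on that carbonyl carbon would compare. Also open, from the compounds shown here alone, is whether the tert-butyl step holds with a longer ester chain.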